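From phenyl to 4-chlorophenyl on compound 1

This account rests on a few compounds, and the source may have more. Where it says the series, first, only, none or still open, it means among the compounds named here.

Among the compounds with values here, in a physicochemical assay, with a stated time of 6 min (a higher number here means a weaker inhibitor, a lower number a stronger inhibitor), compound 1 `O=C(Nc1ccccc1)Nc1nc(-c2cc3cc([N+](=O)[O-])ccc3o2)cs1` gives 183000 nM, the only true number so far, which marks it as a very weak inhibitor. Compound 2 `COc1cccc(NC(=O)Nc2nc(-c3cc4cc(Br)ccc4o3)cs2)c1` reads > 200000 nM, and this is a limit of the assay, not a number. Compound 3 `O=C(Nc1ccc(Cl)cc1)Nc1nc(-c2cc3cc([N+](=O)[O-])ccc3o2)cs1` keeps the core of compound 1 and puts chloro in place of hydrogen on an aromatic carbon, para to a large group (chloro in place of hydrogen on an aromatic carbon), so that phenyl becomes 4-chlorophenyl. Within the data shown here, no measured step shows what such a change does, and compounds 1 and 2 differ in more than one place. In this assay only a small shift towards stronger inhibition is expected, probably no larger than the usual scatter. The estimated step of a 1.5-fold lower number from compound 1 to compound 3 (0.18 log units; within the scatter) is accordingly modest. The estimated value for compound 3 is 120000 nM, with an expected range of 40000 nM to 200000 nM.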

Compound 3, half-maximal inhibitory concentration: 117000 nM
Compound 3: middle estimate off by 1.0-fold (0.01 log units), on the high side; low and high end bracket the measured number.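

In this assay, the series now has its first measured step at this position: chloro in place of hydrogen on an aromatic carbon, para to a large group, gives a 1.6-fold lower number from compound 1 to compound 3 (0.19 log units; within the scatter). Phenyl and 4-chlorophenyl are therefore not separated beyond the scatter, and a single chlorine atom at this place leaves the core of compound 1 in the same very weak range. Compound 1 and compound 3 both give true numbers, while the only other reading in the series is a limit and not a number: the limit of > 200000 nM in this assay, at which 1 of the 3 values shown sits.

Going by these compounds, whether any group at this place can move the number beyond the scatter stays open, since chloro is the only replacement for hydrogen here. An amine or a carboxylic acid on the same ring, or a chloro at another ring position, would test this.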